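Hydroxypiperidine series: removing the methoxyethyl arm

The source may report more compounds than this note shows. Statements on the series, on what has been measured and on what is new or still open speak of the compounds shown alone.

Measured in a functional assay on CHO-K1 cells for antagonist activity at melanin-concentrating hormone receptor 1 (Homo sapiens), read by inositol phosphate accumulation, with stated times of 10 min and 45 min (on this read-out higher numbers stand for weaker inhibition and lower numbers for stronger inhibition), so far:
compound 1 `COCCC1(O)CCN(c2nc(C)c3cc(NC(=O)/C=C/c4ccc(Cl)cc4)ccc3n2)CC1` gives 220 nM
compound 2 `Cc1nc(N2CCC(O)(C3CC3)CC2)nc2ccc(NC(=O)/C=C/c3ccc(Cl)cc3Cl)cc12` gives 575 nM
compound 3 `Cc1nc(NCCNS(C)(=O)=O)nc2ccc(NC(=O)/C=C/c3ccc(OC(F)(F)F)cc3)cc12` gives 142 nM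

Compound 1 carries the second highest of the three numbers in this assay. Compound 3 sits closest, within the usual scatter, so no order between compound 1 and compound 3 can be read. Compound 2 shows a higher number than compound 1, and that gap lies beyond the scatter; compound 2 also differs in the aryl part, so the two values are simply noted side by side.

Compound 4 `Cc1nc(N2CCC(O)CC2)nc2ccc(NC(=O)/C=C/c3ccc(Cl)cc3)cc12` is the next candidate. The change from compound 1 is hydrogen in place of 2-methoxyethyl on a saturated ring carbon. Going by the values given here, no single-point step of this kind has been measured, so the expectation rests on the shape of the change alone: a small step in this assay for compound 4, as a 1.4-fold higher number from compound 1 to compound 4 (0.13 log units; within the scatter), not clearly beyond the scatter in either direction. Compound 4 is estimated at 300 nM, with a range from 100 nM to 900 nM.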

Compound 4, half-maximal inhibitory concentration: 73 nM
For compound 4 the middle estimate is 4.1-fold (0.61 log units) above the measured one; measured number outside the range, below it.
By their numbers in this assay, from the lowest: compounds 4, 3 and 1 (each within the scatter of the next, the first and the last beyond it); then compound 2.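

In this assay, going by these compounds alone, hydrogen in place of 2-methoxyethyl on the saturated ring carbon gives a 3.0-fold lower number from compound 1 to compound 4 (0.48 log units; beyond the scatter), the first single-place step, modest but beyond the scatter. The 2-methoxyethyl arm is therefore not required for inhibition on this aryl amide, as the 4-hydroxypiperidin-1-yl group carries the lower number. No available evidence bears on the reason for this step.

On these data alone, whether a methyl group, an amine or a carboxylic acid on that carbon would keep the lower number stays open. So does whether the step holds with a different aryl part.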